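From Methyl to 4-Methylphenyl on an Aromatic Nitrogen

The source may report more compounds than this note shows. Statements on the series, on what has been measured and on what is new or still open speak of the compounds shown alone.

Compound 1 `COc1cc(-c2nccn2C)cc(OC)c1OC`: > 100000 nM
Compound 2 `COc1cc(-c2nccn2S(=O)(=O)c2ccccc2)cc(OC)c1OC`: > 100000 nM

Within the data shown here, only two compounds have been measured so far, and neither gives an exact number. In a functional assay on T47D cells (Homo sapiens) for antiproliferative activity, read by MTT assay, with a stated time of 72 h (on this read-out lower numbers stand for stronger inhibition and higher numbers for weaker inhibition), compound 1 gives > 100000 nM, which is a limit of the assay and not a number. Compound 2 gives > 100000 nM, and this too is a limit. Compound 1 therefore stands at the limit of > 100000 nM in this assay, at which 2 of the 2 values shown sit.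

Compound 3 `COc1cc(-c2nccn2-c2ccc(C)cc2)cc(OC)c1OC` keeps the core of compound 1 but carries 4-methylphenyl in place of methyl on an aromatic nitrogen of a five-membered aromatic ring with 2 nitrogen: 4-methylphenyl in place of methyl on an aromatic nitrogen. Among the measured compounds shown here, no measured pair shows what such a change does, so any forecast here is uncertain. Since compound 1 offers only a limit as a starting point, compound 3 may well remain at that limit too. Even so, the estimated step of an at least 12-fold lower number from compound 1 to compound 3 (1.09 log units; beyond the scatter) is expected to be large and to point toward stronger inhibition. For compound 3 the expected value is 8000 nM, with an estimated range from 300 nM to 100000 nM.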

Compound 3, half-maximal inhibitory concentration: 20500 nM
For compound 3 the middle estimate is 2.6-fold (0.41 log units) below the measured one; low and high end bracket the measured number.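

In this assay, among these compounds, compound 3 is the first compound here to give an exact number, 20500 nM, so this aromatic nitrogen is a place where a change can bring a compound into the range the assay can read. Compound 1 stands at > 100000 nM, which is a limit of the assay and not a number. Putting 4-methylphenyl in place of methyl therefore gives an at least 4.8-fold lower number from compound 1 to compound 3 (0.68 log units; beyond the scatter), a step whose true size may be larger, and the earlier compounds could show nothing of the kind, since neither gave a number to compare: the limit of > 100000 nM in this assay, at which 2 of the 3 values shown sit.

The compounds shown do not separate the effect of the new six-membered ring from that of the methyl it carries, so a plain phenyl on the same nitrogen would be the direct test. They also leave open how a benzyl group, a longer chain such as butyl, or a phenyl ring carrying an amine or a carboxylic acid in place of that methyl would behave in this assay.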